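This account rests on a few compounds, and the source may have more. Where it says the series, first, only, none or still open, it means among the compounds named here.

In an ADME assay on the whole organism (Rattus norvegicus, strain Sprague-Dawley) for pharmacokinetics, read by LC-MS, with stated times of 5 min and 24 h, at a dose of 5 mg/kg by the oral route (on this read-out lower numbers stand for lower exposure and higher numbers for higher exposure at the dose given), compound 2 `CO[C@H]1CCN(c2cc(NC(=O)N3CCCc4cc(CN5CCOCC5=O)c(C=O)nc43)ncc2C#N)C1` gives 6460 nM and lies within the scatter of the two other measured compounds. Compound 3 `COC[C@@H](C)Nc1cc(NC(=O)N2CCCc3cc(CN4CCCCOC4=O)c(C=O)nc32)ncc1C#N` gives 6470 nM and compound 1 `N#Cc1cnc(NC(=O)N2CCCc3cc(CN4CCOCC4=O)c(C=O)nc32)cc1S[C@H]1CCOC1` gives 4470 nM there. Within the data shown here, compound 4 `N#Cc1cnc(NC(=O)N2CCCc3cc(CN4CCOCC4=O)c(C=O)nc32)cc1S[C@@H]1CCOC1` has no measurement yet. Its change from compound 2 (oxolan-3-yl)sulfanyl in place of 3-methoxypyrrolidin-1-yl on an aromatic carbon puts (oxolan-3-yl)sulfanyl in place of 3-methoxypyrrolidin-1-yl on an aromatic carbon, ortho to a cyano group. Among the measured compounds shown here, one measured step bears on this, the same swap run the other way: a 1.4-fold higher number from compound 1 to compound 2 (0.16 log units; within the scatter) stays within the scatter. No change beyond the scatter is therefore expected in this assay and the estimated step is only a 1.3-fold lower number from compound 2 to compound 4 (0.13 log units; within the scatter) in size. In this assay compound 4 is estimated at 4800 nM with 2400 nM to 9500 nM as its expected range.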

Compound 4, maximal plasma concentration: 3140 nM
Estimate against measurement, compound 4: 1.5-fold (0.18 log units) above; low and high end bracket the measured number.
By their numbers in this assay, from the lowest: compounds 4, 1, 2 and 3 (each within the scatter of the next, the first and the last beyond it).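

In this assay, putting (oxolan-3-yl)sulfanyl in place of 3-methoxypyrrolidin-1-yl gives a 2.1-fold lower number from compound 2 to compound 4 (0.31 log units; beyond the scatter), so with this drawn configuration the swap is a modest step beyond the scatter, which the other configuration did not show. Configuration alone gives a 1.4-fold lower number from compound 1 to compound 4 (0.15 log units; within the scatter), so the two configurations cannot be told apart in this read-out, and that comparison is clean: the fact that compounds 1 and 4 differ only in the configuration as drawn

The compounds shown leave open how exposure would respond to an oxygen-linked group at this position, such as (oxolan-3-yl)oxy, with everything else in compound 4 kept the same.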